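The compounds below may be only part of what the source reports. "The series", "measured", "known", "first", "only" and "open" are said of these compounds alone.

Measured so far:
compound 1 `N#CC1=C(NCN2CCCC2)N(c2ccccc2)C(=O)N2CCCCC(N3CCCC3)C12` — 35.3%
compound 2 `N#CC1=C(/N=C/c2ccccc2)N(c2ccccc2)C(=O)N2CCCCC(N3CCCC3)C12` — 84%

In a functional assay on the whole organism (strain albino) for inhibition, with Rattus norvegicus as the target, read by paw edema, with stated times of 1 h and 3 h, at a dose of 20 mmol/kg by the intraperitoneal route (a lower number here means a weaker effect, a higher number a stronger effect of the compound at the dose given), compound 2 stands highest of the two numbers; its nearest neighbour, compound 1, lies well below it. For the measured compounds named here, the only measured step is a number 48.7 percentage points higher from compound 1 to compound 2 (beyond the scatter), which shows that the group on this double-bonded ring carbon moves the read-out strongly. Compound 3 `CCOC(=O)C(=O)NC1=C(C#N)C2C(N3CCCC3)CCCCN2C(=O)N1c1ccccc1` carries a new group there: a group of 8 heavy atoms (4 carbon, 1 nitrogen, 3 oxygen; no ring) in place of a group of 8 heavy atoms (7 carbon, 1 nitrogen; one six-membered aromatic ring of carbon only), on a double-bonded ring carbon. Going by the values given here, no measured step covers this exact exchange, so only the size of the earlier step guides the expectation. A change of comparable size is expected, and downward, since the group that gave the high number leaves; the expected step is a number 34 percentage points lower from compound 2 to compound 3 (beyond the scatter). Compound 3 is estimated at 50%, within 25% to 78%.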

Compound 3, a percentage reported as inhibition, in the whole organism at one dose (the size of the read-out at that dose, not a potency): 91.5%
Compound 3: middle estimate off by 41.5 percentage points, on the low side; measured number outside the range, above it.
By their numbers in this assay, from the lowest: compound 1; then compounds 2 and 3 (each within the scatter of the next).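

In this assay, an aromatic ring on this double-bonded ring carbon is not required for a high read-out: a number 7.5 percentage points higher from compound 2 to compound 3 (within the scatter), with the ring-free ((ethoxycarbonyl)carbonyl)amino group replacing the group with the six-membered aromatic ring. On the amine nitrogen, (ethoxycarbonyl)carbonyl in place of (pyrrolidin-1-yl)methyl gives a number 56.2 percentage points higher from compound 1 to compound 3 (beyond the scatter), leaving compound 1 apart from the other two. Nothing available accounts for these two dissimilar groups reading alike.

From the compounds shown here alone, whether a carboxylic acid in place of the ethyl ester, or a plain acetyl group on that nitrogen, would keep the read-out in this range remains open. Going by these compounds, how compound 2 and compound 3 compare at lower doses also remains open.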